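One aryl swap on compound 1, outcome still open

The compounds below may be only part of what the source reports. "The series", "measured", "known", "first", "only" and "open" are said of these compounds alone.

Measured in an ADME assay on the whole organism (strain Han-Wistar) for pharmacokinetics, with Rattus norvegicus as the target, read by LC-MS, at a dose of 2 mg/kg by the oral route; on this read-out higher numbers stand for higher exposure at the dose given and lower numbers for lower exposure:
Compound 1 `CN1CCN(CCCS(=O)(=O)c2ccc3nc(NC(=O)NC(=O)c4cccc(-n5cccn5)c4Cl)sc3c2)CC1`: 12 nM
Compound 2 `CCc1ccc(Cl)c(C(=O)NC(=O)Nc2nc3ccc(S(=O)(=O)CCCN4CCN(C)CC4)cc3s2)c1`: 1500 nM

Compound 1, at 12 nM, holds the lower of the two numbers. Compound 3 `CN1CCN(CCCS(=O)(=O)c2ccc3nc(NC(=O)NC(=O)c4cc(-n5cccc5)ccc4Cl)sc3c2)CC1` has not yet been measured and differs from compound 1 as follows: 2-chloro-5-(1H-pyrrol-1-yl)phenyl in place of 2-chloro-3-(1H-pyrazol-1-yl)phenyl on a carbonyl carbon. Among the measured compounds shown here, one measured step bears on this change: a 130-fold higher number from compound 1 to compound 2 (2.10 log units; beyond the scatter), which is large and beyond the scatter, and it removes the same 2-chloro-3-(1H-pyrazol-1-yl)phenyl on a carbonyl carbon. The entering group shares its 2-chloro-5 naming with the 2-chloro-5-ethylphenyl of compound 2, at 1500 nM, yet it keeps a five-membered aromatic ring, so part of that rise is expected, not all of it. For the measured compounds named here, no measured compound carries the new group. The expected change in this assay is upward, a 13-fold higher number from compound 1 to compound 3 (1.10 log units; beyond the scatter). Compound 3 is estimated at 150 nM, with an expected range of 25 nM to 900 nM.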

Compound 3, maximal plasma concentration: 580 nM
Compound 3: the middle estimate sits 3.9-fold (0.59 log units) below what was measured; low and high end bracket the measured number.
By their numbers in this assay, from the lowest: compound 1; then compound 3; then compound 2.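

In this assay, moving to 2-chloro-5-(1H-pyrrol-1-yl)phenyl gives a 48-fold higher number from compound 1 to compound 3 (1.68 log units; beyond the scatter), so the low number of compound 1 does not follow from a five-membered aromatic ring on this aryl group alone. Placing 1H-pyrrol-1-yl instead of ethyl on an aromatic carbon gives a 2.6-fold lower number from compound 2 to compound 3 (0.41 log units; beyond the scatter), a modest step next to the large one, so most of the gain survives with the ring kept. Nothing measured here gives a reason for either step.

The change from compound 1 to compound 3 alters both the ring and where it is named on the phenyl, and the compounds shown do not separate the two. A 2-chloro-5-(1H-pyrazol-1-yl)phenyl group would speak to that, while a methoxy group in place of the ethyl would test how far the trend extends beyond these groups.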